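Swapping methoxy for fluoro on a shared pyrazoline-thiazole core

This account rests on a few compounds, and the source may have more. Where it says the series, first, only, none or still open, it means among the compounds named here.

A small set of three closely related compounds has been measured in a functional assay on B16-F10 cells (Mus musculus) for antiproliferative activity, read by MTT assay, with a stated time of 48 h; a higher number here means a weaker inhibitor, a lower number a stronger inhibitor. Compound 1 `COc1ccc(-c2csc(N3N=C(c4ccc(F)cc4)CC3c3ccc4c(c3)OCCO4)n2)cc1` gives 4430 nM. Compound 2 `COc1ccc(-c2csc(N3N=C(c4ccc(Cl)cc4)CC3c3ccc4c(c3)OCCO4)n2)cc1` gives 3120 nM, and the step from compound 1 to compound 2 is a 1.4-fold lower number from compound 1 to compound 2 (0.15 log units; within the scatter). Compound 3 `COc1ccc(C2=NN(c3nc(-c4ccc(Br)cc4)cs3)C(c3ccc4c(c3)OCCO4)C2)cc1` gives 2520 nM; its number sits within the usual scatter of the numbers of compound 2 and compound 1, so the three cannot be told apart on this evidence.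

Compound 4 `Fc1ccc(C2=NN(c3nc(-c4ccc(Br)cc4)cs3)C(c3ccc4c(c3)OCCO4)C2)cc1` has not yet been measured. It differs from compound 3 in one place: fluoro in place of methoxy on an aromatic carbon. Within the data shown here, no measured pair in this set varies the same position, so no step directly bears on the change. Among the measured compounds shown here, the only measured step, the halogen exchange from compound 1 to compound 2, stayed within the scatter, which gives a weak hint that small changes on an outer aryl ring leave this assay largely untouched. On that basis compound 4 is expected to show a 1.2-fold higher number from compound 3 to compound 4 (0.08 log units; within the scatter), a step not beyond the scatter, and its estimated value in this assay is 3000 nM, with a range from 1200 nM to 8000 nM.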

Compound 4, half-maximal inhibitory concentration: 4110 nM
Estimate against measurement, compound 4: 1.4-fold (0.14 log units) below, within the range that was stated.
By their numbers in this assay, from the lowest: compounds 3, 2, 4 and 1 (each within the scatter of the next).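

In this assay, the exchange of 4-methoxyphenyl for 4-fluorophenyl gives a 1.6-fold higher number from compound 3 to compound 4 (0.21 log units; within the scatter), so this place on the shared core now has a direct test, and the two groups cannot be told apart there. Bromo in place of methoxy on the other outer aryl ring gives a 1.1-fold lower number from compound 1 to compound 4 (0.03 log units; within the scatter), which also stays within the scatter, so all three single-place exchanges in this set leave the compounds indistinguishable. No accompanying measurement offers an explanation for these results.

On these data alone, what an amine, a carboxylic acid or a longer chain such as butoxy would do at this place remains open, as does whether any group there can move the number beyond the scatter. Also open, as far as these compounds go, is whether fluoro and methoxy would still match with chloro instead of bromo on the other aryl ring.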